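From 4-methoxyphenyl to 4-fluorophenyl: working notes

A few compounds are considered here, and "the series" means these few. Any claim that something is new, unique, unknown or untested is made for them only; others in the source may bear on it.

Within the data shown here, in a functional assay on SGC-7901 cells (Homo sapiens) for antiproliferative activity, read by MTT assay, with a stated time of 72 h (a lower number here means a stronger inhibitor, a higher number a weaker inhibitor), compound 3 `COc1ccc(-c2ccc3ncn(-c4cc(OC)c(OC)c(OC)c4)c3c2)cc1` gives 82 nM, the lowest of the three numbers so far and the strongest inhibitor of the set. Compound 2 `COc1cc(-n2cnc3ccc(-c4ccccc4)cc32)cc(OC)c1OC` gives 290 nM, and compound 1 `COc1ccc(-c2ccc3ncn(-c4cc(OC)c(OC)c(OC)c4)c3c2)cc1F` gives 430 nM. The step between these two is a 1.5-fold lower number from compound 1 to compound 2 (0.17 log units; within the scatter).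

Compound 4 `COc1cc(-n2cnc3ccc(-c4ccc(F)cc4)cc32)cc(OC)c1OC` is not yet measured. It carries fluoro in place of methoxy on an aromatic carbon, para to a large group, so that 4-methoxyphenyl becomes 4-fluorophenyl: fluoro in place of methoxy on an aromatic carbon.

Among the measured compounds shown here, two measured steps bear on this change. Methoxy in place of hydrogen gave a 3.5-fold lower number from compound 2 to compound 3 (0.55 log units; beyond the scatter), so losing the methoxy of compound 3 is expected to raise the number by a similar amount. Hydrogen in place of fluoro gave a 5.2-fold lower number from compound 1 to compound 3 (0.72 log units; beyond the scatter), which points the same way but carries over only loosely, since compound 1 also keeps its methoxy. For the measured compounds named here, no measured pair shows fluoro replacing methoxy directly, so the uncertainty is wide.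

In this assay the expected result is a 3.0-fold higher number from compound 3 to compound 4 (0.48 log units; beyond the scatter), a modest step beyond the scatter. For compound 4 the estimated value is 250 nM, with an expected range of 90 nM to 700 nM.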

Compound 4, half-maximal inhibitory concentration: 3500 nM
Compound 4: the middle estimate sits 14-fold (1.15 log units) below what was measured; the whole stated range lies below it.
By their numbers in this assay, from the lowest: compound 3; then compounds 2 and 1 (each within the scatter of the next); then compound 4.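

In this assay, among these compounds, the position para to a large group tolerates fluoro far worse than the earlier compounds suggested: fluoro in place of methoxy gives a 43-fold higher number from compound 3 to compound 4 (1.63 log units; beyond the scatter), and fluoro in place of hydrogen gives a 12-fold higher number from compound 2 to compound 4 (1.08 log units; beyond the scatter), so at this position fluoro gives a higher number than no substituent at all. The 4-fluorophenyl group also falls short of the 3-fluoro-4-methoxyphenyl group, with an 8.1-fold higher number from compound 1 to compound 4 (0.91 log units; beyond the scatter), so the compound with two changes relative to compound 3 is not the poorest of the set. Hydrogen in place of fluoro now lowers the number to a comparable degree in two settings, one with the methoxy kept and one without it: the same change on two cores in this assay, a 5.2-fold lower number (0.72 log units; beyond the scatter) from compound 1 to compound 3 and a 12-fold lower number (1.08 log units; beyond the scatter) from compound 4 to compound 2, 2.3-fold (0.36 log units) apart, within the scatter of two such steps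

The compounds shown leave open whether the loss is particular to fluoro or extends to other groups at this position, which chloro, hydroxyl or a dimethylamino group would help to separate. They also leave open whether the benefit of methoxy over hydrogen continues with a longer chain such as ethoxy or propoxy.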